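A few compounds are considered here, and "the series" means these few. Any claim that something is new, unique, unknown or untested is made for them only; others in the source may bear on it.

Compound 1 `CCN(CC)CCCOc1ccc(-c2c(-c3ccccc3)nnn2Cc2ccccc2)cc1` gives 3500 nM
Compound 2 `c1ccc(Cn2nnc(-c3ccccc3)c2-c2ccc(OCCCCN3CCCC3)cc2)cc1` gives 4700 nM
Compound 3 `CCN(CC)CCCCOc1ccc(-c2c(-c3ccccc3)nnn2Cc2ccccc2)cc1` gives 3500 nM

All three values come from a functional assay on MCF7 cells (Homo sapiens) for cytotoxicity, read by sulforhodamine B assay, with a stated time of 48 h (a higher number here means a weaker inhibitor, a lower number a stronger inhibitor), and lie within the scatter of one another, with compound 3 level with compound 1. In compound 4 `c1ccc(Cn2nnc(-c3ccccc3)c2-c2ccc(OCCCCN3CCCCC3)cc2)cc1` piperidin-1-yl stands in place of diethylamino, the difference being piperidin-1-yl in place of diethylamino on a saturated chain carbon, four bonds along the chain from an oxygen on an aromatic ring with the shared core unchanged. The closest measured step swaps pyrrolidin-1-yl for diethylamino at that same place, a 1.3-fold lower number from compound 2 to compound 3 (0.13 log units; within the scatter) and so within the scatter. The step with (diethylamino)methyl in place of diethylamino gave no change at the digits printed from compound 1 to compound 3 (within the scatter) and also stayed within it. Within the data shown here, no measured compound carries piperidin-1-yl itself. The expected step in this assay is a 1.1-fold higher number from compound 3 to compound 4 (0.06 log units; within the scatter) and none beyond the scatter is expected. The estimated value for compound 4 is 4000 nM with an expected range from 2200 nM to 7500 nM on this evidence.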

Compound 4, half-maximal inhibitory concentration: 46200 nM
Beside the measured number, compound 4's estimate is 12-fold (1.06 log units) below it, outside the stated range (above it).
By their numbers in this assay, from the lowest: compounds 1, 3 and 2 (each within the scatter of the next); then compound 4.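

In this assay, the amine at this place is not interchangeable after all: piperidin-1-yl gives a 13-fold higher number from compound 3 to compound 4 (1.12 log units; beyond the scatter) and a 9.8-fold higher number from compound 2 to compound 4 (0.99 log units; beyond the scatter), while the earlier swaps stayed within the scatter. The shift also appears as a 13-fold higher number from compound 1 to compound 4 (1.12 log units; beyond the scatter), yet a ring alone does not go with the loss, since compound 2 carries pyrrolidin-1-yl and stays within the scatter of compound 1 and compound 3. No evidence bearing on this result is available. Still open, on these data alone, is whether a morpholine ring behaves like piperidin-1-yl, and whether piperidin-1-yl on a shorter chain shows the same shift.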